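The source may report more compounds than this note shows. Statements on the series, on what has been measured and on what is new or still open speak of the compounds shown alone.

Measured compounds and values:

Compound 1, `COc1ccc(-n2c(SC)nnc2-c2cc(OC)c(OC)c(OC)c2)cc1`: in a functional assay on HepG2 cells (Homo sapiens) for inhibition, read by MTT assay, with a stated time of 48 h (a lower number here means a stronger inhibitor, a higher number a weaker inhibitor), compound 1 gives > 60000 nM, which is a limit of the assay rather than a number.
Compound 2, `COc1ccc(-n2c(SCc3ccccc3)nnc2-c2cc(OC)c(OC)c(OC)c2)cc1`: in this assay compound 2 gives > 60000 nM, again a limit rather than a number.
Compound 3, `COc1ccc(-n2c(SCC(=O)c3ccc(OC)c(O)c3)nnc2-c2cc(OC)c(OC)c(OC)c2)cc1`: in this assay compound 3 gives > 60000 nM, also a limit rather than a number.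

Compound 2 therefore has no measured number, only a limit, and the same is true of the two other compounds shown. The new compound is compound 4, `COc1ccc(-n2c(SCC(=O)c3ccc4ccccc4c3)nnc2-c2cc(OC)c(OC)c(OC)c2)cc1`. Compared with compound 2 it carries (naphthalen-2-yl)carbonyl in place of phenyl on a saturated chain carbon bound to a sulfur.

The closest measured comparison is the exchange of the same phenyl for another aryl carbonyl group, a step that the two limits leave unreadable from compound 2 to compound 3. The steps a step that the two limits leave unreadable from compound 1 to compound 2 and a step that the two limits leave unreadable from compound 1 to compound 3 are likewise not readable in size, because of the limit of > 60000 nM in this assay, at which 3 of the 3 values shown sit. For the measured compounds named here, no measured step therefore says whether adding an aryl carbonyl at this position changes inhibition at all, and no direction can be drawn from the shared core.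

With every value sitting at the limit, the expectation for compound 4 is that it too will most likely return only a limit, so the step that the limit leaves unreadable from compound 2 to compound 4 is expected to be no readable change. Compound 4 is estimated at 80000 nM, in the range 30000 nM to 300000 nM.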

Compound 4, half-maximal inhibitory concentration: > 60000 nM
Compound 4 was reported as a limit; the forecaster's own chance of this, stated with the estimate: 80%; the middle value is on the limit's open side.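

In this assay compound 4 gives > 60000 nM, which is a limit and not a number. For the compounds shown here, no step between compound 4 and compound 1, compound 2 or compound 3 can be read in size, because all four stop at the same point: the limit of > 60000 nM in this assay, at which 4 of the 4 values shown sit. The compounds shown leave open whether any group on the saturated chain carbon bound to a sulfur changes inhibition at all.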